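Diaminoquinoxaline series: arylthio for dichlorophenoxy at the ring carbon

A few compounds are considered here, and "the series" means these few. Any claim that something is new, unique, unknown or untested is made for them only; others in the source may bear on it.

Measured compounds in a functional assay on HOP-62 cells (Homo sapiens) for inhibition, read by sulforhodamine B assay, with a stated time of 48 h; a higher number here means a weaker inhibitor of growth, a lower number a stronger inhibitor of growth:
compound 1 `Nc1cc(N)c2nc(-c3ccccc3)c(Oc3ccc(Cl)c(Cl)c3)nc2c1`: 17000 nM
compound 2 `CCOC(=O)[C@H](CCC(=O)O)NC(=O)c1ccc(Sc2nc3cc(N)cc(N)c3nc2-c2ccccc2)cc1`: 15500 nM
compound 3 `COc1cc(CNc2nc3cc(N)cc(N)c3nc2-c2ccccc2)cc(OC)c1OC`: 17000 nM

Compound 1 stands level with compound 3 at the digits given, and the two together hold the highest numbers of the three. Compound 2 lies a shade lower, but that gap is within the scatter, so the three measured compounds cannot be ordered against one another in this assay; all sit at the same weak level of growth inhibition.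

Compound 4 `COc1ccc(Sc2nc3cc(N)cc(N)c3nc2-c2ccccc2)cc1` is not yet measured. It differs from compound 1 in one place: (4-methoxyphenyl)sulfanyl in place of 3,4-dichlorophenoxy on an aromatic carbon. The shared core of compound 1 and the phenyl group beside the change are kept. For the measured compounds named here, no pair of measured compounds differing in one place exists in this set, so no measured step can be read for guidance; compound 2 carries a sulfanyl-linked aryl group at the same position and gives 15500 nM, which does not stand apart from compound 1.

On that basis the step from compound 1 to compound 4 is expected to be small, in no particular direction, and not beyond the scatter: a 1.1-fold lower number from compound 1 to compound 4 (0.05 log units; within the scatter). Compound 4 is thus estimated at 15000 nM, with a range of 5000 nM to 45000 nM, the width allowing for the absence of any single-change step in the data.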

Compound 4, concentration for 50% growth inhibition: < 100000 nM
Compound 4: no number, only a limit; the forecaster's own chance of this, stated with the estimate: 15%; the middle value is on the limit's open side.
By their numbers in this assay, from the lowest: compounds 2, 1 and 3 (each within the scatter of the next).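

In this assay compound 4 gives < 100000 nM, a limit and not a number. No step from compound 1 to compound 4 can therefore be read against this limit: the limit of < 100000 nM in this assay, at which 1 of the 4 values shown sits.

The compounds shown leave open whether (4-methoxyphenyl)sulfanyl in place of 3,4-dichlorophenoxy on the shared core changes growth inhibition, and in which direction.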